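This account rests on a few compounds, and the source may have more. Where it says the series, first, only, none or still open, it means among the compounds named here.

In a functional assay on CHO-K1 cells for antagonist activity at C-X-C chemokine receptor type 3 (Homo sapiens), read by FLIPR, with a stated time of 10 min (on this read-out lower numbers stand for stronger inhibition and higher numbers for weaker inhibition), three compounds have been measured:

compound 1 `C[C@@H]1CN(c2sc(C3CC3)nc2-c2nc3ccccc3[nH]2)CCN1C(=O)Cn1cnc2cccnc21` gives 9.7 nM
compound 2 `CCCc1ncc(-c2nc(C(F)(F)F)sc2N2CCN(C(=O)Cn3cnc4cccnc43)[C@H](C)C2)cn1` gives 3.3 nM
compound 3 `CCCc1ncc(-c2nc(C(F)(F)F)sc2N2CCN(C(=O)Cn3nc(C)nc3C)[C@H](C)C2)cn1` gives 4.4 nM

Compound 3 stands second highest of the three numbers. Its nearest neighbour is compound 2; the step of a 1.3-fold higher number from compound 2 to compound 3 (0.12 log units; within the scatter) lies within the scatter, so the two cannot be told apart. Among the compounds with values here, the one step beyond the scatter separates it from compound 1, whose number is the highest of the three.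

Compound 4 `Cc1nc(C)n(CC(=O)N2CCN(c3sc(C(F)(F)F)nc3-c3ccc(C(F)(F)F)nc3)C[C@H]2C)n1` is not yet measured. It differs from compound 3 in one place: 6-(trifluoromethyl)pyridin-3-yl in place of 2-propylpyrimidin-5-yl on an aromatic carbon. None of the measured steps touches this position; the single step shown, from compound 2 to compound 3, exchanges the group on the saturated chain carbon bound to the carbonyl and says nothing about the aromatic ring that now changes. The comparison of compound 1 with compounds 2 and 3 alters several groups at once and gives no clean reading either. Within the data shown here, with no bearing step, the expectation for compound 4 is a number close to compound 3, with a wide range in either direction: the estimated step is a 1.4-fold higher number from compound 3 to compound 4 (0.13 log units; within the scatter), and compound 4 is expected at 6 nM, between 1.5 nM and 25 nM.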

Compound 4, half-maximal inhibitory concentration: 4.2 nM
Compound 4: the middle estimate sits 1.4-fold (0.15 log units) above what was measured; measured number inside the range.
By their numbers in this assay, from the lowest: compounds 2, 4 and 3 (each within the scatter of the next); then compound 1.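

Within the data shown here, this is the first reading at this position, the aromatic carbon next to the ring nitrogen of the five-membered aromatic ring. In this assay the exchange of 2-propylpyrimidin-5-yl for 6-(trifluoromethyl)pyridin-3-yl gives a 1.0-fold lower number from compound 3 to compound 4 (0.02 log units; within the scatter) and so produces no change that can be told from scatter, even though the propyl chain gives way to a trifluoromethyl group and the ring loses a nitrogen. No measurement shown here offers an explanation for this result.

The compounds shown leave open whether this position would stay as accepting of a pyridine ring carrying a carboxylic acid or a primary amine in place of the trifluoromethyl group, or of a pyrimidine ring carrying a hexyl chain in place of the propyl chain. Among these compounds, they also leave open whether the same exchange would read alike when the carbonyl side carries the group found in compound 2 rather than the one shared by compound 3 and compound 4.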